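The source may report more compounds than this note shows. Statements on the series, on what has been measured and on what is new or still open speak of the compounds shown alone.

The series shares the core of compound 1, `COCCN(C)S(=O)(=O)c1ccc(C)c(C#Cc2cc(Cl)ccc2OCC(=O)O)c1`, which in an in vitro ADME assay on microsomes from liver (Rattus norvegicus) for metabolic stability, read by LC-MS, tested at 1 uM (on this read-out higher numbers stand for fast clearance and lower numbers for slow clearance), gives 49 mL.min-1.g-1. Compound 2, `Cc1ccc(S(=O)(=O)NC(C)C)cc1C#Cc1cc(Cl)ccc1OCC(=O)O`, gives 12 mL.min-1.g-1 in this assay. Compound 3, `CCCS(=O)(=O)c1ccc(F)c(C#Cc2cc(Cl)ccc2OCC(=O)O)c1`, is reported in this assay only as a limit, < 10 mL.min-1.g-1. Among the two numbers actually measured, compound 2 stands lowest; the nearest step to it is a 4.1-fold lower number from compound 1 to compound 2 (0.61 log units; beyond the scatter), which came with isopropylamino in place of (2-methoxyethyl)(methyl)amino on a sulfonyl sulfur.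

Compound 4, `Cc1ccc(S(C)(=O)=O)cc1C#Cc1cc(Cl)ccc1OCC(=O)O`, has not yet been measured in this assay. It differs from compound 2 in a single place: methyl in place of isopropylamino on a sulfonyl sulfur. Going by the values given here, the only measured step at the same position is a 4.1-fold lower number from compound 1 to compound 2 (0.61 log units; beyond the scatter), which moved the number downward when the group on the sulfonyl sulfur was exchanged. Compound 3, which also lacks isopropylamino, sits at the limit of < 10 mL.min-1.g-1 in this assay, at which 1 of the 3 values shown sits. Yet compound 3 differs from compound 2 in more than one place, so no single step connects them. On this basis compound 4 is expected to move somewhat further down or to stay within the scatter, a step of a 1.5-fold lower number from compound 2 to compound 4 (0.18 log units; within the scatter). Compound 4 is therefore estimated at 8 mL.min-1.g-1, with a range from 4 mL.min-1.g-1 to 16 mL.min-1.g-1.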

Compound 4, intrinsic clearance in microsomes: 18 mL.min-1.g-1
Compound 4: middle estimate off by 2.3-fold (0.35 log units), on the low side; measured number outside the range, above it.
By their numbers in this assay, from the lowest: compounds 2 and 4 (each within the scatter of the next); then compound 1. At a limit, below all of these: compound 3.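

In this assay, the exchange of isopropylamino for methyl on a sulfonyl sulfur, which turns isopropylsulfamoyl into methylsulfonyl, gives a 1.5-fold higher number from compound 2 to compound 4 (0.18 log units; within the scatter) and shows that this position can lose the nitrogen and its hydrogen-bond donor without a change beyond the scatter. The comparison with the (2-methoxyethyl)(methyl)amino group gives a 2.7-fold lower number from compound 1 to compound 4 (0.43 log units; beyond the scatter) and shows that the lower number seen in the earlier step does not depend on keeping a nitrogen on the sulfonyl sulfur, since methyl and isopropylamino both stand apart from compound 1 in the same direction. Nothing measured here gives a cause for either step.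

Going by these compounds, how a longer chain ending in an amine or in a carboxylic acid would behave on the sulfonyl sulfur remains open, as the three groups compared so far cannot show which feature of the (2-methoxyethyl)(methyl)amino group goes with its higher number. Compound 3 is reported only as a limit, < 10 mL.min-1.g-1, and it differs from the other compounds in more than one place, so it does not settle this question.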